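Fluoro to methoxy on two cores: edema inhibition

This account rests on a few compounds, and the source may have more. Where it says the series, first, only, none or still open, it means among the compounds named here.

Compound 1 `Cc1ccc(-c2nn(-c3ccc(Cl)cc3)cc2C(CC(=O)c2ccc(Cl)cc2)C(=O)c2ccc(F)cc2)cc1` and compound 2 `COc1ccc(C(=O)C(CC(=O)c2ccc(Cl)cc2)c2cn(-c3ccc(Cl)cc3)nc2-c2ccc(C)cc2)cc1` share one core; compound 3 `COc1ccc(-c2nn(-c3ccc(S(N)(=O)=O)cc3)cc2C(CC(=O)c2ccc(Cl)cc2)C(=O)c2ccc(F)cc2)cc1` and compound 4 `COc1ccc(C(=O)C(CC(=O)c2ccc(Cl)cc2)c2cn(-c3ccc(S(N)(=O)=O)cc3)nc2-c2ccc(OC)cc2)cc1` share another. The difference between the two cores is not broken down here. In a functional assay on the whole organism (strain Wistar albino) for inhibition, with Rattus norvegicus as the target, read by paw edema, with stated times of 1 h and 3 h, at a dose of 0.32 mmol/kg by the intraperitoneal route (a higher number here means more inhibition at the dose given (going by the name of the read-out), a lower number less inhibition), compound 1 gives 19.4% and compound 2 gives 23.9%; the change between them, (methoxy in place of fluoro on an aromatic carbon), made a step of a number 4.5 percentage points higher from compound 1 to compound 2 (within the scatter). Compound 3 gives 68.1% in this assay, the highest of the three numbers, and its gap to compound 2 and to compound 1 lies beyond the scatter in both cases.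

Compound 4 carries the same change as compound 2, (methoxy in place of fluoro on an aromatic carbon), which occurs twice among these compounds and at a place described in the same words both times. The expected step from compound 3 to compound 4 in this assay is a number 2.9 percentage points higher from compound 3 to compound 4 (within the scatter), set beside the earlier one and resting on compound 1 and compound 2, whose step a number 4.5 percentage points higher from compound 1 to compound 2 (within the scatter) stayed within the scatter. For compound 4 the expected value in this assay is 71%, with a range from 58% to 82%.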

Compound 4, a percentage reported as inhibition, in the whole organism at one dose (the size of the read-out at that dose, not a potency): 22.5%
For compound 4 the middle estimate is 48.5 percentage points above the measured one, and the stated range ends above it.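

In this assay, methoxy in place of fluoro on an aromatic carbon does not carry over from the core of compound 1 to the core of compound 3, so the step on one core gives no reliable estimate for the other: the same change on two cores in this assay, a number 4.5 percentage points higher (within the scatter) from compound 1 to compound 2 and a number 45.6 percentage points lower (beyond the scatter) from compound 3 to compound 4, 50.1 percentage points apart, beyond the scatter of two such steps

On the core of compound 3 the change gives a number 45.6 percentage points lower from compound 3 to compound 4 (beyond the scatter), whereas on the core of compound 1 it gives a number 4.5 percentage points higher from compound 1 to compound 2 (within the scatter); the outcome of this change therefore depends on the core in these two pairs. This does not show which of the differences between the two cores is responsible or why, and two pairs read at a single dose establish no rule for the series and say nothing about potency.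

Going by these compounds, it remains open whether a hydroxyl or an amine in place of fluoro on the core of compound 3 would stay close to compound 3 or fall towards compound 4. Also open, on these data alone, is which single difference between the cores would be enough to make the fluoro and methoxy compounds separate.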